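This account rests on a few compounds, and the source may have more. Where it says the series, first, only, none or still open, it means among the compounds named here.

Compound 2 `O=C(/C=C/c1cccc(O)c1)c1cccc(-n2cc(-c3ccc(Cl)cc3)[nH]c2=O)c1` gives the highest of the two numbers recorded in a functional assay on A498 cells (Homo sapiens) for inhibition; a lower number here means a stronger inhibitor of growth, a higher number a weaker inhibitor of growth: compound 2 gives 3710 nM. Its nearest neighbour is compound 1 `COc1cc(/C=C/C(=O)c2cccc(-n3cc(-c4ccccc4)[nH]c3=O)c2)ccc1O`, which in this assay gives 1680 nM, a lower number that lies beyond the usual scatter; the two compounds differ in more than one place, so only their values can be compared. Compound 3 `O=C(/C=C/c1cccc(O)c1)c1cccc(-n2cc(-c3ccccc3)[nH]c2=O)c1` differs from compound 2 by hydrogen in place of chloro on an aromatic carbon. Going by the values given here, with no single-change step measured here, the expected step from compound 2 to compound 3 in this assay is a 1.2-fold lower number from compound 2 to compound 3 (0.09 log units; within the scatter), none beyond the scatter. Compound 3 is therefore estimated at 3000 nM, with a range from 1200 nM to 7500 nM.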

Compound 3, concentration for 50% growth inhibition: 14300 nM
The estimate for compound 3 lay 4.8-fold (0.68 log units) below the measured number; measured number outside the range, above it.
By their numbers in this assay, from the lowest: compound 1; then compound 2; then compound 3.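

In this assay the chloro on this aromatic carbon, para to a large group, counts: hydrogen in its place gives a 3.9-fold higher number from compound 2 to compound 3 (0.59 log units; beyond the scatter) and thus a weaker inhibitor of growth. With the phenyl held fixed, the other end of the molecule also matters, since 3-hydroxyphenyl in place of 4-hydroxy-3-methoxyphenyl accounts for an 8.5-fold higher number from compound 1 to compound 3 (0.93 log units; beyond the scatter) and again weakens inhibition. Nothing available explains either step.

As far as these compounds go, whether bromo, methoxy or an amine would serve at this position as chloro does stays open. So does whether chloro would count equally alongside the 4-hydroxy-3-methoxyphenyl group.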